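Methoxy against tert-butyl on a diiodophenol hydrazone pair

The source may hold more compounds than are shown below. What is called first, only, known or untested is meant among the compounds shown, and "the series" means these compounds.

Measured compounds:
compound 1 `COc1ccc(C(=O)N/N=C/c2cc(I)cc(I)c2O)cc1`: 45200 nM
compound 2 `CC(C)(C)c1ccc(C(=O)N/N=C/c2cc(I)cc(I)c2O)cc1`: 41600 nM
compound 3 `COc1ccc(C(=O)N/N=C/c2cc(I)c(O)c(I)c2)cc1`: > 100000 nM

In a functional assay on HepG2 cells (Homo sapiens) for cytotoxicity, with a stated time of 24 h (on this read-out lower numbers stand for stronger inhibition and higher numbers for weaker inhibition), compound 1 gives 45200 nM and compound 2 gives 41600 nM. The change between them is tert-butyl in place of methoxy on an aromatic carbon, and the step is a 1.1-fold lower number from compound 1 to compound 2 (0.04 log units; within the scatter). For compound 3 this assay reports only a limit, > 100000 nM, the bound described by the limit of > 100000 nM in this assay, at which 1 of the 3 values shown sits. Compound 3 shares its atoms with compound 1 but joins them differently; the difference between the two cores is not broken down here. Compound 4 `CC(C)(C)c1ccc(C(=O)N/N=C/c2cc(I)c(O)c(I)c2)cc1` has not yet been measured. It differs from compound 3 by tert-butyl in place of methoxy on an aromatic carbon, the same change as made from compound 1 to compound 2. For compound 4 the expected value in this assay is 120000 nM, between 50000 nM and 300000 nM, a step that the limit leaves unreadable from compound 3 to compound 4, resting on the earlier step of a 1.1-fold lower number from compound 1 to compound 2 (0.04 log units; within the scatter) lying within the scatter and on the limit reported for compound 3.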

Compound 4, half-maximal inhibitory concentration: 45900 nM
For compound 4 the middle estimate is 2.6-fold (0.42 log units) above the measured one, outside the stated range (below it).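

Carried to the second core, tert-butyl in place of methoxy gives an at least 2.1-fold lower number from compound 3 to compound 4 (0.33 log units; beyond the scatter) in this assay. Compound 3 is reported only as a limit, > 100000 nM. Set beside the earlier step, this shows a lower number on the second core but does not show whether the change acts alike or differently on the two cores, and the full size of the second step stays unknown: the same change on two cores in this assay, a 1.1-fold lower number (0.04 log units; within the scatter) from compound 1 to compound 2 and an at least 2.1-fold lower number (0.33 log units; beyond the scatter) from compound 3 to compound 4; the limit leaves it open whether they differ

The compounds shown leave open whether an amine, a carboxylic acid or a longer chain on that aromatic carbon would shift the number on either core. Nor do they tell whether a further core would follow either of these two.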